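Pyrrolidine versus piperidine on the propoxy chain

The compounds below may be only part of what the source reports. "The series", "measured", "known", "first", "only" and "open" are said of these compounds alone.

Measured compounds:
compound 1 `COc1cc2c(Oc3ccc(NC(=O)c4cc(-c5ccc(C)cc5)ccn4)cc3F)ccnc2cc1OCCCN1CCCC1` gives 440 nM in a functional assay on MKN-45 cells (Homo sapiens) for cytotoxicity, read by MTT assay, with a stated time of 72 h; a higher number here means a weaker inhibitor, a lower number a stronger inhibitor
compound 2 `COc1cc2c(Oc3ccc(NC(=O)c4cc(-c5ccc(C)cc5)ccn4)cc3F)ccnc2cc1OCCCN1CCCCC1` gives 1670 nM in this assay
compound 3 `COc1cc2c(Oc3ccc(NC(=O)c4nccc(-c5ccccc5)n4)cc3F)ccnc2cc1OCCCN1CCCCC1` gives 1030 nM in this assay

Compound 2 and compound 1 share one core and differ in a single place: pyrrolidin-1-yl in place of piperidin-1-yl on a saturated chain carbon, three bonds along the chain from an oxygen on an aromatic ring. That change yields a 3.8-fold lower number from compound 2 to compound 1 (0.58 log units; beyond the scatter). Compound 3 carries a different core; the difference between the cores of compound 2 and compound 3 is not broken down here, and the two values of compound 2 and compound 3 lie within the scatter of each other, so no order between them is claimed.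

Compound 4 `COc1cc2c(Oc3ccc(NC(=O)c4nccc(-c5ccccc5)n4)cc3F)ccnc2cc1OCCCN1CCCC1` has not been measured. Relative to compound 3 it shows the same change, at a place described in identical words: pyrrolidin-1-yl in place of piperidin-1-yl on a saturated chain carbon, three bonds along the chain from an oxygen on an aromatic ring. The change is seen in measured form only once, on the core of compound 1 and compound 2, so any transfer to the core of compound 3 rests on one step. In this assay compound 4 is expected around 330 nM, with a range from 150 nM to 800 nM. From the compounds shown here alone, this corresponds to an estimated step of a 3.1-fold lower number from compound 3 to compound 4 (0.49 log units; beyond the scatter), set a little less steep than a 3.8-fold lower number from compound 2 to compound 1 (0.58 log units; beyond the scatter); whether the step carries across cores is untested.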

Compound 4, half-maximal inhibitory concentration: 1360 nM
For compound 4 the middle estimate is 4.1-fold (0.62 log units) below the measured one; measured number outside the range, above it.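

In this assay, pyrrolidin-1-yl in place of piperidin-1-yl gives a 1.3-fold higher number from compound 3 to compound 4 (0.12 log units; within the scatter), so the clear shift seen on the core of compound 1 does not reappear on the core of compound 3. The change therefore does not carry between these two cores as a fixed step: the same change on two cores in this assay, a 3.8-fold lower number (0.58 log units; beyond the scatter) from compound 2 to compound 1 and a 1.3-fold higher number (0.12 log units; within the scatter) from compound 3 to compound 4, 5.0-fold (0.70 log units) apart, beyond the scatter of two such steps With a single pair on each core, this does not show which part of the difference between the cores is tied to the result, nor which of the two steps is more typical of the series.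

Left open is how the core of compound 1 and the core of compound 3 respond to other amines at the end of the chain, such as morpholin-4-yl or dimethylamino. Also open, from the compounds shown here alone, is whether the same pair of rings behaves alike on a longer chain than 3-(piperidin-1-yl)propyl or on further cores.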